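The source may report more compounds than this note shows. Statements on the series, on what has been measured and on what is new or still open speak of the compounds shown alone.

Measured so far: compound 1 `CC(C)[C@H](C(=O)Nc1ccccn1)c1ccc(Cl)cc1` at 1400 nM; compound 2 `CC(C)C(C(=O)Nc1cnccn1)c1ccc(Cl)cc1` at 5700 nM; compound 3 `CC(C)C(C(=O)Nc1nnn[nH]1)c1ccc(Cl)cc1` at 100000 nM.

In a functional assay on CHO cells for agonist activity at Free fatty acid receptor 2 (Homo sapiens), read by cAMP accumulation (on this read-out lower numbers stand for stronger inhibition and higher numbers for weaker inhibition), compound 1 gives the lowest number of the three, with compound 2 nearest and compound 3 furthest. Compound 4 `CC(C)[C@H](C(=O)Nc1cnns1)c1ccc(Cl)cc1` differs from compound 1 by 1,2,3-thiadiazol-5-yl in place of pyridin-2-yl on an amide-type nitrogen. Among the measured compounds shown here, the one single-place step measured, an 18-fold higher number from compound 2 to compound 3 (1.24 log units; beyond the scatter), is a large loss when a six-membered ring gives way to a five-membered ring rich in hetero atoms; the values of compound 1 and compound 2 further show the pyrazin-2-yl analogue above the pyridin-2-yl one. Compound 4 carries a five-membered ring with three hetero atoms but no hydrogen-bond donor, so a moderate rise in this assay is expected, a 5.0-fold higher number from compound 1 to compound 4 (0.70 log units; beyond the scatter). For compound 4 the estimate is 7000 nM (range 1500 nM to 40000 nM).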

Compound 4, half-maximal inhibitory concentration: 57000 nM
For compound 4 the middle estimate is 8.1-fold (0.91 log units) below the measured one; measured number outside the range, above it.
By their numbers in this assay, from the lowest: compound 1; then compound 2; then compounds 4 and 3 (each within the scatter of the next).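

In this assay, the step to 1,2,3-thiadiazol-5-yl on the amide-type nitrogen is large, a 41-fold higher number from compound 1 to compound 4 (1.61 log units; beyond the scatter), so a five-membered ring with 0 hydrogen-bond donors does not keep the number near that of compound 1. The large step seen earlier, an 18-fold higher number from compound 2 to compound 3 (1.24 log units; beyond the scatter), therefore need not depend on a donor in the entering ring. No measurement at hand accounts for the size of this rise.

Still open, on these data alone, is whether a thiazol-2-yl or phenyl group on this nitrogen would keep the number near that of compound 1.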